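Amine substituents on the shared core and lipophilicity

The compounds below may be only part of what the source reports. "The series", "measured", "known", "first", "only" and "open" are said of these compounds alone.

Measured so far in a physicochemical assay for lipophilicity; on this read-out higher numbers stand for higher lipophilicity and lower numbers for lower lipophilicity:
compound 1 `CC(C)Sc1nnc(-c2c(CNCCN3CCCC3)c3cc(F)ccc3n2C)n1-c1ccccc1` — 4.99
compound 2 `CC(C)Sc1nnc(-c2c(CNC3CC3)c3ccccc3n2C)n1-c1ccccc1` — 4.81
compound 3 `CC1CCCN(Cc2c(-c3nnc(SC(C)C)n3-c3ccccc3)n(C)c3ccc(F)cc23)C1` — 6.18

Compound 2 gives the lowest of the three numbers; compound 1 sits within the scatter of it, while compound 3 stands beyond the scatter above both. The change to compound 4 `CC(C)Sc1nnc(-c2c(CN3CCCCC3C)c3ccccc3n2C)n1-c1ccccc1` is 2-methylpiperidin-1-yl in place of cyclopropylamino on a saturated chain carbon bound to an aromatic carbon. Among the measured compounds shown here, the one measured step that bears on it is a number 1.19 log units higher from compound 1 to compound 3 (beyond the scatter), where (2-(pyrrolidin-1-yl)ethyl)amino gives way to 3-methylpiperidin-1-yl on a saturated chain carbon bound to an aromatic carbon; that rise was large. A step of similar direction and size is therefore expected in this assay for compound 4, a number 1.09 log units higher from compound 2 to compound 4 (beyond the scatter). For compound 4 the expected value is 5.9, with a range from 5.4 to 6.4.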

Compound 4, partition coefficient: 5.95
For compound 4 the middle estimate is 0.05 log units below the measured one; the measured number falls inside the stated range.
By their numbers in this assay, from the lowest: compounds 2 and 1 (each within the scatter of the next); then compounds 4 and 3 (each within the scatter of the next).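

In this assay, the rise seen with a methylpiperidin-1-yl group on a saturated chain carbon bound to an aromatic carbon also appears with a different amine leaving and on a core without fluorine, a number 1.14 log units higher from compound 2 to compound 4 (beyond the scatter), so both listed steps are large and upward. Here cyclopropylamino, with 1 hydrogen-bond donor, gives way to 2-methylpiperidin-1-yl, with 0 hydrogen-bond donors. Nothing available explains the size of this rise. 

Open, from the compounds shown here alone, is how piperidin-1-yl without the methyl, or morpholin-4-yl, would read at this place. Also open, going by these compounds, is how 2-methylpiperidin-1-yl and 3-methylpiperidin-1-yl compare on one identical core.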